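This account rests on a few compounds, and the source may have more. Where it says the series, first, only, none or still open, it means among the compounds named here.

Compound 1 `CO[C@@H]1[C@H](OC(=O)NC(=O)CCl)CO[C@]2(COC(C)(C)O2)[C@@]1(O)C1(C)CO1`: 84000 nM
Compound 2 `CO[C@@H]1[C@H](OC(=O)NC(=O)CCl)CO[C@]2(COC(C)(C)O2)[C@@]1(OC)C1(C)CO1`: 39000 nM
Compound 3 `CO[C@@H]1[C@H](OC(=O)NC(=O)CCl)CO[C@]2(COC(C)(C)O2)[C@@]1(O)C1OC1CC(C)C`: 44000 nM; 44000 nM (2 entries)

All three were tested in a functional assay on A-431 cells (Homo sapiens) for antiproliferative activity; on this read-out lower numbers stand for stronger inhibition and higher numbers for weaker inhibition. Of the two compounds with a single reading, compound 1 has the higher number, so it is the weaker of that pair. The nearest value is a 2.2-fold lower number from compound 1 to compound 2 (0.33 log units; beyond the scatter). Compound 3 was recorded twice, and it has no single number to place in this comparison.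

The next compound is compound 4 `CO[C@@H]1[C@H](OC(=O)NC(=O)c2ccccc2)CO[C@]2(COC(C)(C)O2)[C@@]1(O)C1(C)CO1`, which keeps the core of compound 1 but puts phenyl in place of chloromethyl on a carbonyl carbon. For the measured compounds named here, the swap brings in a larger group with an aromatic ring, yet none of the measured compounds changes this group. Going by the values given here, the only measured step is a 2.2-fold lower number from compound 1 to compound 2 (0.33 log units; beyond the scatter), a modest change made elsewhere, as methyl in place of hydrogen on an oxygen on a saturated carbon. That step gives a rough idea of how far one small edit has moved the number in this set, but it says nothing about direction here. With no direction to go on, the expected change is a 1.1-fold lower number from compound 1 to compound 4 (0.02 log units; within the scatter), which amounts to no clear step beyond the scatter. For compound 4 the estimated value is 80000 nM, with an expected range of 28000 nM to 220000 nM.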

Compound 4, half-maximal inhibitory concentration: > 500000 nM
Compound 4 gave a limit, no number; the forecaster's own chance of this, stated with the estimate: 25%; at least 6.2-fold (0.79 log units) between middle value and limit.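

Among the compounds shown, only compound 4 changes the group on this carbonyl carbon, and in this assay the swap of chloromethyl for phenyl gives an at least 5.9-fold higher number from compound 1 to compound 4 (0.77 log units; beyond the scatter). For the compounds shown here, since a higher number means weaker inhibition, this position is not indifferent to what sits on it, and this change moves activity in the weakening direction, whereas the only earlier step, a 2.2-fold lower number from compound 1 to compound 2 (0.33 log units; beyond the scatter), went the other way at a different place on the molecule. The reading for compound 4 is a limit of the assay and not a number, so the true size of the step stays unknown: the limit of > 500000 nM in this assay, at which 1 of the 4 values shown sits.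

A single swap also cannot separate the loss of chloromethyl from the arrival of phenyl, since both happen at once. From the compounds shown here alone, it remains open whether a plain methyl, a bromomethyl or a longer chain such as propyl on the same carbonyl carbon would stay close to compound 1 or behave like compound 4, and whether the benzamido group would act the same way on the cores of compound 2 and compound 3.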